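Swapping a Cyclopentyl for a Cyclopropyl on a Triazolopyrimidine

The compounds below may be only part of what the source reports. "The series", "measured", "known", "first", "only" and "open" are said of these compounds alone.

Three compounds share a core and differ in two places: the ring attached to a nitrogen on an aromatic ring, and a single group on a pendant six-membered ring. Compound 3 `Clc1ccccc1Cn1nnc2c(NC3CCCC3)nc(-c3ccccc3)nc21` carries cyclopentyl and chloro. In an assay on isolated protein for binding affinity to adenosine receptor A1 (Bos taurus) (on this read-out higher numbers stand for weaker inhibition and lower numbers for stronger inhibition), compound 3 gives 9000000 nM. Compound 1 `Clc1ccccc1Cn1nnc2c(NC3CC3)nc(-c3ccccc3)nc21` keeps the chloro but carries cyclopropyl instead; the difference is cyclopropyl in place of cyclopentyl on a nitrogen on an aromatic ring. In this assay compound 1 gives 11000000 nM, and the step is a 1.2-fold higher number from compound 3 to compound 1 (0.09 log units; within the scatter). Compound 2 `FC(F)(F)c1ccccc1Cn1nnc2c(NC3CCCC3)nc(-c3ccccc3)nc21` keeps the cyclopentyl but carries trifluoromethyl; the difference from compound 3 is trifluoromethyl in place of chloro on an aromatic carbon. In this assay compound 2 gives 600000 nM, the lowest of the three, with the step of a 15-fold higher number from compound 2 to compound 3 (1.18 log units; beyond the scatter).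

Compound 4 `FC(F)(F)c1ccccc1Cn1nnc2c(NC3CC3)nc(-c3ccccc3)nc21` has not yet been measured. It differs from compound 2 by cyclopropyl in place of cyclopentyl on a nitrogen on an aromatic ring, the same change as from compound 3 to compound 1, made at the same kind of place. Since that earlier step was a 1.2-fold higher number from compound 3 to compound 1 (0.09 log units; within the scatter) and stayed within the scatter, the expected step from compound 2 to compound 4 is a 1.2-fold higher number from compound 2 to compound 4 (0.07 log units; within the scatter). On that basis compound 4 is estimated at 700000 nM, with a likely range from 300000 nM to 1600000 nM. This rests on a single precedent, so the range is kept wide.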

Compound 4, inhibition constant: 7800000 nM
Compound 4: middle estimate off by 11-fold (1.05 log units), on the low side, outside the stated range (above it).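

With trifluoromethyl on the pendant ring, cyclopropyl in place of cyclopentyl gives a 13-fold higher number from compound 2 to compound 4 (1.11 log units; beyond the scatter) in this assay, so a change that stayed within the scatter on the chloro compounds does not carry over unchanged to the trifluoromethyl compounds: the same change on two cores in this assay, a 1.2-fold higher number (0.09 log units; within the scatter) from compound 3 to compound 1 and a 13-fold higher number (1.11 log units; beyond the scatter) from compound 2 to compound 4, 11-fold (1.03 log units) apart, beyond the scatter of two such steps. Read the other way, trifluoromethyl in place of chloro gives a 1.4-fold lower number from compound 1 to compound 4 (0.15 log units; within the scatter) when cyclopropyl is present, a step within the scatter, although the same swap gives a large step when cyclopentyl is present: the same change on two cores in this assay, a 15-fold higher number (1.18 log units; beyond the scatter) from compound 2 to compound 3 and a 1.4-fold higher number (0.15 log units; within the scatter) from compound 4 to compound 1, 11-fold (1.03 log units) apart, beyond the scatter of two such steps. The two changes therefore do not act independently of each other here, and both large steps lead away from compound 2, but one pair of steps for each change cannot show why this happens or how either change would behave on any other core.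

As far as these compounds go, it remains open whether the low number of compound 2 depends on cyclopentyl specifically, or whether cyclobutyl, cyclohexyl or a longer chain such as n-butyl in that place would give a similar number alongside trifluoromethyl. From the compounds shown here alone, it is also open whether a group such as fluoro, methoxy or nitrile in place of trifluoromethyl would show the same dependence on the ring attached to the nitrogen.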